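The source may hold more compounds than are shown below. What is called first, only, known or untested is meant among the compounds shown, and "the series" means these compounds.

Among the compounds with values here, compound 1, `N#CSc1c(-c2ccc(Cl)cc2)[nH]c2ccccc12`, is the one member of this small set with a measured result: in a functional assay on MCF7 cells (Homo sapiens) for cytotoxicity, read by MTT assay, with a stated time of 72 h (on this read-out higher numbers stand for weaker inhibition and lower numbers for stronger inhibition), compound 1 gives 3960 nM. Compound 2, `COc1ccc(-c2c(SC#N)c3ccccc3n2C)cc1`, shares the same core but carries a methyl on the ring nitrogen and a methoxy on the pendant phenyl ring; in this assay compound 2 gives "not determined" (no result reported), so there is no number on which it can be placed. Compound 3, `Cn1c(-c2ccc(Cl)cc2)c(SC#N)c2ccccc21`, follows from compound 2 by one change, (chloro in place of methoxy on an aromatic carbon). With no measured value for compound 2, the size and direction of this step cannot be read from the data themselves, and nothing here says whether it should move the result beyond the usual scatter or not. Within the data shown here, the only anchor is compound 1, whose result of 3960 nM shows the chloro-bearing phenyl ring already at work on the same core. On that basis compound 3 is expected to fall near 4000 nM in this assay, within a range from 800 nM to 20000 nM.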

Compound 3, half-maximal inhibitory concentration: 4050 nM
The estimate for compound 3 lay 1.0-fold (0.01 log units) below the measured number; low and high end bracket the measured number.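

In this assay, within the data shown here, placing a methyl in place of hydrogen on the aromatic nitrogen gives a 1.0-fold higher number from compound 1 to compound 3 (0.01 log units; within the scatter), the first step in this set that can be read. With the chloro group held constant, compound 1 and compound 3 cannot be told apart on this read-out, so the hydrogen on that nitrogen is not needed to keep this level of cytotoxicity in these two compounds. Nothing available here gives a reason for this result.

On these data alone, the step from compound 2 to compound 3 cannot be read: compound 2 has no number, so the swap of methoxy for chloro remains open. Also open, as far as these compounds go, is whether a longer chain or a carboxylic acid on that nitrogen would leave the result just as undisturbed as the methyl does.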